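The source may report more compounds than this note shows. Statements on the series, on what has been measured and on what is new or still open speak of the compounds shown alone.

For the measured compounds named here, compound 2 `COc1cc(-n2cnc3ccc(-c4cccc(F)c4)cc32)cc(OC)c1OC` stands at the higher of the two numbers so far: in a functional assay on SGC-7901 cells (Homo sapiens) for antiproliferative activity, read by MTT assay, with a stated time of 72 h (on this read-out higher numbers stand for weaker inhibition and lower numbers for stronger inhibition), compound 2 gives 2490 nM, while compound 1 `COc1cc(-n2cnc3ccc(-c4ccc(C(F)(F)F)cc4)cc32)cc(OC)c1OC` gives 890 nM. Going by the values given here, the one step between them is a 2.8-fold higher number from compound 1 to compound 2 (0.45 log units; beyond the scatter). Compound 3 `COc1cc(-n2cnc3ccc(-c4ccc(Cl)cc4)cc32)cc(OC)c1OC` differs from compound 2 by 4-chlorophenyl in place of 3-fluorophenyl on an aromatic carbon. Among the compounds with values here, only that one step bears on the change, and compound 3 shares with compound 1 the placement of its substituent, 4-chlorophenyl against 4-(trifluoromethyl)phenyl, so a modest step toward lower numbers is expected, a 1.9-fold lower number from compound 2 to compound 3 (0.28 log units; within the scatter), with a wide range given a single precedent. Compound 3 is estimated at 1300 nM, between 500 nM and 3500 nM.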

Compound 3, half-maximal inhibitory concentration: 1270 nM
Compound 3: the middle estimate sits 1.0-fold (0.01 log units) above what was measured; the measured number falls inside the stated range.
By their numbers in this assay, from the lowest: compounds 1, 3 and 2 (each within the scatter of the next, the first and the last beyond it).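

The step of a 2.0-fold lower number from compound 2 to compound 3 (0.29 log units; within the scatter) and the step of a 1.4-fold higher number from compound 1 to compound 3 (0.15 log units; within the scatter) both stay within the scatter, so compound 3 cannot be separated from either neighbour, even though compound 1 and compound 2 stand apart. Chloro and trifluoromethyl are not told apart here, and 4-chlorophenyl for 3-fluorophenyl changes both the halogen and its place on the phenyl at once. No evidence on the cause of these numbers is available.

On these data alone, whether the halogen or its place matters stays open, and a 4-fluorophenyl would separate the two. Also open, as far as these compounds go, is how an amine or a carboxylic acid on that phenyl would read.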